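Oxetane on the pyrazole nitrogen of an LRRK2 inhibitor

A few compounds are considered here, and "the series" means these few. Any claim that something is new, unique, unknown or untested is made for them only; others in the source may bear on it.

Compound 3 `C[C@@H]1CCCN1c1c(C#N)c2c(N)nc(Nc3cn(C)nc3Cl)nc2n1C` sits in the middle of three compounds in an assay on isolated protein for inhibition of Leucine-rich repeat serine/threonine-protein kinase 2 (Homo sapiens), read by TR-FRET and LanthaScreen, with stated times of 50 min and 30 min, in the presence of a further agent that is not named here (a lower number here means a stronger inhibitor, a higher number a weaker inhibitor), where compound 3 gives 34 nM, compound 1 `Cc1c(Nc2nc(N)c3c(C#N)c(N4CCC[C@H]4C)n(C)c3n2)cnn1C` gives 75 nM and compound 2 `Cc1c(Nc2nc(N)c3c(C#N)c(N4CCC[C@H]4C)n(C)c3n2)cnn1CC1(O)COC1` gives 16 nM. Compound 4 `Cc1c(Nc2nc(N)c3c(C#N)c(N4CCC[C@H]4C)n(C)c3n2)cnn1C1COC1` differs from compound 3 by 5-methyl-1-(oxetan-3-yl)-1H-pyrazol-4-yl in place of 3-chloro-1-methyl-1H-pyrazol-4-yl on a nitrogen on an aromatic ring. Among the compounds with values here, two measured steps bear on this. Going from compound 1 to compound 3 gave a 2.2-fold lower number from compound 1 to compound 3 (0.34 log units; beyond the scatter), so returning to the methyl-bearing pyrazole of compound 1 should cost about that much. Going from compound 1 to compound 2 gave a 4.7-fold lower number from compound 1 to compound 2 (0.67 log units; beyond the scatter) on adding 3-hydroxyoxetan-3-yl to the nitrogen-bound methyl, which suggests an oxetane on that nitrogen may recover the loss. Together these give an expected step of a 1.1-fold lower number from compound 3 to compound 4 (0.05 log units; within the scatter). Compound 4 is therefore expected to give 30 nM, estimated between 12 nM and 80 nM.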

Compound 4, half-maximal inhibitory concentration: 47 nM
The estimate for compound 4 lay 1.6-fold (0.19 log units) below the measured number; the measured number falls inside the stated range.
By their numbers in this assay, from the lowest: compound 2; then compounds 3, 4 and 1 (each within the scatter of the next, the first and the last beyond it).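

In this assay, oxetan-3-yl in place of methyl on the aromatic nitrogen gives a 1.6-fold lower number from compound 1 to compound 4 (0.20 log units; within the scatter), so the ring alone changes little. Oxetan-3-yl in place of (3-hydroxyoxetan-3-yl)methyl gives a 2.9-fold higher number from compound 2 to compound 4 (0.47 log units; beyond the scatter), so the gain seen with that group does not come with the oxetane ring alone. Exchanging the whole pyrazole group gives a 1.4-fold higher number from compound 3 to compound 4 (0.14 log units; within the scatter), which also stays within the scatter. Nothing measured here explains these steps. Going by these compounds, whether an azetidin-3-yl amine, or a longer chain ending in a carboxylic acid, on that nitrogen would match the (3-hydroxyoxetan-3-yl)methyl group stays open.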